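The compounds below may be only part of what the source reports. "The series", "measured", "known", "first", "only" and "open" are said of these compounds alone.

Compound 2 `CCCCCC(CCCCC)n1ccc2cc(/C(C)=C/C(=O)Nc3ccccc3OCCCC(=O)O)ccc21` stands lowest of the two numbers in an assay on Prostate gland for inhibition of steroid 5-alpha-reductase (Rattus norvegicus) (on this read-out higher numbers stand for weaker inhibition and lower numbers for stronger inhibition), where compound 2 gives 25 nM; compound 1 `C/C(=C\C(=O)Nc1ccccc1OCCCC(=O)O)c1ccc2c(ccn2CC(C)C)c1` gives 160 nM. Going by the values given here, the only measured step, a 6.4-fold lower number from compound 1 to compound 2 (0.81 log units; beyond the scatter), also altered the group on the aromatic nitrogen. Compound 3 `CCCCCC(c1ccccc1)n1ccc2cc(/C(C)=C/C(=O)Nc3ccccc3OCCCC(=O)O)ccc21` differs from compound 2 by phenyl in place of pentyl on a saturated chain carbon bound to an aromatic nitrogen and a saturated chain carbon. Among the compounds with values here, no measured step exchanges a chain for a ring at this place, so that step is only a loose guide, and compound 3 is expected to give 30 nM (range 12 nM to 75 nM), an expected step of a 1.2-fold higher number from compound 2 to compound 3 (0.08 log units; within the scatter) that stays within the scatter.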

Compound 3, half-maximal inhibitory concentration: 25 nM
Estimate against measurement, compound 3: 1.2-fold (0.08 log units) above, within the range that was stated.
By their numbers in this assay, from the lowest: compounds 2 and 3 (each within the scatter of the next); then compound 1.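

In this assay, a phenyl ring can replace pentyl on this saturated chain carbon without moving the number (with no change at the digits printed from compound 2 to compound 3 (within the scatter)), so an open chain is not needed at this place. The 1-phenylhexyl group also keeps the drop seen against isobutyl (with a 6.4-fold lower number from compound 1 to compound 3 (0.81 log units; beyond the scatter)). No measurement offered here explains why the ring and the chain read alike. Still open, as far as these compounds go, is whether the remaining pentyl can also give way to a ring, as in diphenylmethyl, and whether an amine on the phenyl ring would keep the number.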